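A few compounds are considered here, and "the series" means these few. Any claim that something is new, unique, unknown or untested is made for them only; others in the source may bear on it.

Notes on an ester series built on a shared core. Compound 1 `CCOC(=O)CCC(=O)N1CCN(CCCOc2cc3c(Nc4ccc(F)c(Cl)c4)ncnc3cc2OC)CC1` gives 67.4% in a functional assay on A549 cells (Homo sapiens) for cytotoxicity, read by MTT assay, with a stated time of 24 h, tested at 40 uM; on this read-out higher numbers stand for a weaker effect at the one concentration tested and lower numbers for a stronger effect. Compound 2 `CCCOC(=O)CCC(=O)N1CCN(CCCOc2cc3c(Nc4ccc(F)c(Cl)c4)ncnc3cc2OC)CC1` gives 80.9% in this assay; it differs from compound 1 by methyl in place of hydrogen on a saturated chain carbon, two bonds along the chain from an oxygen next to a carbonyl group, the step being a number 13.5 percentage points higher from compound 1 to compound 2 (beyond the scatter). Compound 3 `CCCCCOC(=O)CCC(=O)N1CCN(CCCOc2cc3c(Nc4ccc(F)c(Cl)c4)ncnc3cc2OC)CC1` gives 63.6% in this assay; its core differs from that of compound 1 by propyl in place of hydrogen on a saturated chain carbon, two bonds along the chain from an oxygen next to a carbonyl group, with the step of a number 3.8 percentage points lower from compound 1 to compound 3 (within the scatter), while a number 17.3 percentage points lower from compound 2 to compound 3 (beyond the scatter) lies beyond the scatter. Compound 4 `CCCCCCOC(=O)CCC(=O)N1CCN(CCCOc2cc3c(Nc4ccc(F)c(Cl)c4)ncnc3cc2OC)CC1` is not yet measured; it differs from compound 3 by methyl in place of hydrogen on a saturated chain carbon, five bonds along the chain from an oxygen next to a carbonyl group. This is the same kind of change as that from compound 1 to compound 2, not the same: there the place lay two bonds along the chain from an oxygen next to a carbonyl group, here five bonds. Since chain growth across compounds 1, 2 and 3 shows no steady direction, the expected step is small, a number 1.4 percentage points higher from compound 3 to compound 4 (within the scatter), set beside the measured a number 13.5 percentage points higher from compound 1 to compound 2 (beyond the scatter). Compound 4 is expected to give about 65%, between 50% and 80%.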

Compound 4, a percentage reported as activity, at one concentration (the size of the read-out at that concentration, not a potency): 74.2%
Compound 4: the middle estimate sits 9.2 percentage points below what was measured; the measured number falls inside the stated range.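

In this assay, methyl in place of hydrogen, five bonds along the chain from an oxygen next to a carbonyl group, gives a number 10.6 percentage points higher from compound 3 to compound 4 (beyond the scatter), and this step agrees with the same kind of change on the other core: the same change on two cores in this assay, a number 13.5 percentage points higher (beyond the scatter) from compound 1 to compound 2 and a number 10.6 percentage points higher (beyond the scatter) from compound 3 to compound 4, 2.9 percentage points apart, within the scatter of two such steps

Propyl in place of hydrogen, three bonds along the chain, gives a number 6.7 percentage points lower from compound 2 to compound 4 (within the scatter), and it also agrees with its counterpart: the same change on two cores in this assay, a number 3.8 percentage points lower (within the scatter) from compound 1 to compound 3 and a number 6.7 percentage points lower (within the scatter) from compound 2 to compound 4, 2.9 percentage points apart, within the scatter of two such steps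

Among the compounds shown here, this shows agreement between only two pairs per change, with the methyl steps at different places on the chain, and it gives no steady trend with chain length, as butyl in place of hydrogen gives a number 6.8 percentage points higher from compound 1 to compound 4 (within the scatter) while compound 2 and compound 3 go in opposite directions.

Going by these compounds, a longer chain than that of compound 4, a branched chain and a carboxylic acid in place of the ester remain open.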